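A few compounds are considered here, and "the series" means these few. Any claim that something is new, unique, unknown or untested is made for them only; others in the source may bear on it.

Compound 1, with the structure `CCC(CC)(c1ccc(OCCCCCCO)c(C)c1)c1ccc(OCC(O)C(C)(C)C)c(OCC(O)C(C)(C)C)c1`, and compound 2, with the structure `CCC(CC)(c1ccc(OCCCCCCCO)c(C)c1)c1ccc(OCC(O)C(C)(C)C)c(OCC(O)C(C)(C)C)c1`, share one core, and so do compound 3, with the structure `CCC(CC)(c1ccc(OCCCCC(=O)O)c(C)c1)c1ccc(OCC(O)C(C)(C)C)c(OCC(O)C(C)(C)C)c1`, and the still unmeasured compound 4, with the structure `CCC(CC)(c1ccc(OCCCCCC(=O)O)c(C)c1)c1ccc(OCC(O)C(C)(C)C)c(OCC(O)C(C)(C)C)c1`. In an assay on cells for binding affinity to vitamin D3 receptor (Homo sapiens), read by fluorescence, tested at 1 uM (a lower number here means less inhibition, a higher number more inhibition at the concentration tested (going by the name of the read-out)), compound 1 gives 52%, and compound 2 gives 5%. Among the measured compounds shown here, the only step joining two measured compounds is a number 47 percentage points lower from compound 1 to compound 2 (beyond the scatter), a change that makes the chain one carbon longer. Compound 3 stands apart: in this assay compound 3 is reported as "not active" (no number reported), with no single number to anchor it. The change to compound 4 is carboxymethyl in place of carboxy on a saturated chain carbon, four bonds along the chain from an oxygen on an aromatic ring. That is again a chain made one carbon longer, the kind of change that in the step from compound 1 to compound 2 cost a large share of the inhibition. Starting from a compound reported as not active, nothing in these data points to a higher number, so for compound 4 a low read-out is expected, estimated at 5%, within 0% to 25%.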

Compound 4, a percentage reported as inhibition, at one concentration (the size of the read-out at that concentration, not a potency): "not active" (no number reported)
Compound 4: no number reported, and the estimate cannot be compared.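

In this assay, among the compounds shown here, compound 3 gives "not active" (no number reported) and compound 4 gives "not active" (no number reported), so no step between them can be read. No other data bear on this result. The compounds shown leave open whether carboxymethyl in place of carboxy changes the inhibition at all.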